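The source may report more compounds than this note shows. Statements on the series, on what has been measured and on what is new or still open speak of the compounds shown alone.

Compound 1 `COc1ccc(C(=O)NC[C@H]2c3[nH]c4ccccc4c3C[C@H]3[C@H]4c5[nH]c6ccccc6c5C[C@@H]([C@H](C#N)N23)N4C)cc1` gives 840 nM in a functional assay on HT-29 cells (Homo sapiens) for cytotoxicity, read by MTT assay, with a stated time of 72 h; on this read-out higher numbers stand for weaker inhibition and lower numbers for stronger inhibition
Compound 2 `CCc1ccc(C(=O)NC[C@H]2c3[nH]c4ccccc4c3C[C@H]3[C@H]4c5[nH]c6ccccc6c5C[C@@H]([C@H](C#N)N23)N4C)cc1` gives 3560 nM
Compound 3 `CN1[C@@H]2c3[nH]c4ccccc4c3C[C@H]1[C@H](C#N)N1[C@@H](CNC(=O)c3cc4ccccc4[nH]3)c3[nH]c4ccccc4c3C[C@@H]21` gives 1220 nM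

Compound 3 stands second highest of the three numbers in this assay: compound 1 is nearest, with a 1.5-fold higher number from compound 1 to compound 3 (0.16 log units; within the scatter), while compound 2 is furthest, with a 2.9-fold lower number from compound 2 to compound 3 (0.47 log units; beyond the scatter). Compound 4 `COc1ccc(/C=C/C(=O)NC[C@H]2c3[nH]c4ccccc4c3C[C@H]3[C@H]4c5[nH]c6ccccc6c5C[C@@H]([C@H](C#N)N23)N4C)cc1` differs from compound 3 by 2-(4-methoxyphenyl)ethenyl in place of 1H-indol-2-yl on a carbonyl carbon. Among the measured compounds shown here, two measured steps bear on this change. a 1.5-fold higher number from compound 1 to compound 3 (0.16 log units; within the scatter) shows that 1H-indol-2-yl and 4-methoxyphenyl on this carbonyl give numbers within the scatter, and a 4.2-fold higher number from compound 1 to compound 2 (0.63 log units; beyond the scatter) shows that the 4-methoxyphenyl carbonyl carries the lower number of the two aryl amides. For the measured compounds named here, no measured step tells what the ethenyl link between carbonyl and 4-methoxyphenyl does. Compound 4 is therefore expected to show a 1.2-fold lower number from compound 3 to compound 4 (0.09 log units; within the scatter), a step not expected to exceed the scatter. The estimate for compound 4 is 1000 nM, with a range from 300 nM to 3500 nM.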

Compound 4, half-maximal inhibitory concentration: 3060 nM
Estimate against measurement, compound 4: 3.1-fold (0.49 log units) below; the range from low to high includes it.
By their numbers in this assay, from the lowest: compounds 1 and 3 (each within the scatter of the next); then compounds 4 and 2 (each within the scatter of the next).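

Extending the 4-methoxyphenyl group to 2-(4-methoxyphenyl)ethenyl on this carbonyl carbon is not a neutral change: the number rises, with a 3.6-fold higher number from compound 1 to compound 4 (0.56 log units; beyond the scatter) and a 2.5-fold higher number from compound 3 to compound 4 (0.40 log units; beyond the scatter). With a 1.2-fold lower number from compound 2 to compound 4 (0.07 log units; within the scatter), the two compounds are not separated, so the four amides form two groups, compounds 1 and 3 at the lower numbers and compounds 2 and 4 at the higher. Nothing available explains this difference.

As far as these compounds go, what a saturated chain in place of the ethenyl link would give remains open. So does the effect of an amine or a carboxylic acid in place of the methoxy group.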